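The compounds below may be only part of what the source reports. "The series", "measured", "known", "first", "only" and "open" are said of these compounds alone.

The measured compounds in a functional assay on B16-F10 cells (Mus musculus) for inhibition, read by MTT assay, with a stated time of 72 h; a lower number here means a stronger inhibitor, a higher number a weaker inhibitor:

Compound 1, `N#Cc1c(Nc2ccc(F)cc2)nc(SCc2cn(Cc3ccccc3Cl)nn2)nc1-c1ccccc1`, gives 5340 nM.
Compound 2, `Cc1ccccc1Nc1nc(SCc2cn(Cc3ccc(Cl)cc3)nn2)nc(-c2ccccc2)c1C#N`, reaches only a limit of the assay, > 64000 nM.
Compound 3, `Cc1ccc(Nc2nc(SCc3cn(Cc4ccc(Cl)cc4)nn3)nc(-c3ccccc3)c2C#N)cc1`, gives 15100 nM.

Compound 3 therefore holds the highest of the two numbers that were actually reached, with compound 1 the nearer of the two and lower by a margin beyond the scatter. Compound 2 sits at the limit of > 64000 nM in this assay, at which 1 of the 3 values shown sits.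

Among the compounds with values here, only one step between measured compounds differs in a single place: an at least 4.2-fold lower number from compound 2 to compound 3 (0.62 log units; beyond the scatter). That step moves the methyl on the phenyl on the nitrogen and says nothing about the halogen on the benzyl group.

Compound 4, `Cc1ccc(Nc2nc(SCc3cn(Cc4ccc(F)cc4)nn3)nc(-c3ccccc3)c2C#N)cc1`, differs from compound 3 by fluoro in place of chloro on an aromatic carbon. Within the data shown here, no measured pair differs at this position, so none of the measured steps bears on the change, and the expectation in this assay is a step that stays within the scatter, in no particular direction.

Compound 4 is accordingly estimated to give 15000 nM in this assay, with a range from 5000 nM to 45000 nM. That estimate means a step of a 1.0-fold lower number from compound 3 to compound 4 (0.00 log units; within the scatter), expected to lie within the scatter.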

Compound 4, half-maximal inhibitory concentration: 3040 nM
Compound 4: middle estimate off by 4.9-fold (0.69 log units), on the high side; measured number outside the range, below it.
By their numbers in this assay, from the lowest: compounds 4 and 1 (each within the scatter of the next); then compound 3. At a limit, above all of these: compound 2.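

In this assay, the halogen on the 4-chlorobenzyl group proves to matter: fluoro in place of chloro gives a 5.0-fold lower number from compound 3 to compound 4 (0.70 log units; beyond the scatter), a step beyond the scatter. Within the data shown here, the only earlier single-place step concerned the methyl on the phenyl on the nitrogen, so this is the first reading of how the number responds at the benzyl end of the series, and it shows that this position is not silent in this assay, even though one halogen atom simply replaces another with no change in ring, hydrogen-bond donors, hydrogen-bond acceptors or net charge. Nothing given here accounts for the size or direction of this step.

The compounds shown leave open how this position would respond to a group other than these two halogens, such as bromo, methoxy or an amine, and whether fluoro would give a step of similar size with a different group on the nitrogen of the shared core. Also open, from the compounds shown here alone, is whether fluoro on another carbon of the same ring, or a longer chain in place of the benzyl methylene, would keep the lower number.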